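The source may report more compounds than this note shows. Statements on the series, on what has been measured and on what is new or still open speak of the compounds shown alone.

Among the measured compounds shown here, compound 2 `CC[C@@H](C)/N=c1\c(O)c(O)\c1=N/Cc1ccc(C#N)cc1` is the only compound in this set with a measured number in a functional assay for inhibition, with Rattus norvegicus as the target; a higher number here means a weaker inhibitor, a lower number a stronger inhibitor: compound 2 gives 4000 nM. Compound 1 `CCCC/N=c1\c(O)c(O)\c1=N/Cc1ccc(C#N)cc1` differs from it only in the chain on the double-bonded nitrogen. In this assay compound 1 gives > 30000 nM, which is a limit of the assay rather than a number. The step between the two is an at least 7.5-fold lower number from compound 1 to compound 2 (0.87 log units; beyond the scatter), read against (the limit of > 30000 nM in this assay, at which 1 of the 2 values shown sits). Compound 3 `CC(C)/N=c1\c(O)c(O)\c1=N/Cc1ccc(C#N)cc1` is the next step from compound 2: hydrogen in place of methyl on a saturated chain carbon, two bonds along the chain from a double-bonded nitrogen. For the measured compounds named here, the one measured step concerns the shape of the chain on the double-bonded nitrogen, butyl against sec-butyl, and compound 3 keeps that branched pattern while losing only the terminal methyl. Going by the values given here, no measured step tests such a shortening of the chain, so in this assay compound 3 is expected to move only a little from its parent, a 1.3-fold higher number from compound 2 to compound 3 (0.10 log units; within the scatter). The estimate for compound 3 is therefore 5000 nM, within a range from 2000 nM to 15000 nM.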

Compound 3, half-maximal inhibitory concentration: 14000 nM
Compound 3: the middle estimate sits 2.8-fold (0.45 log units) below what was measured; the range from low to high includes it.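

In this assay, the terminal methyl of the sec-butyl group is not a neutral feature of this chain: removing it gives a 3.5-fold higher number from compound 2 to compound 3 (0.54 log units; beyond the scatter), whereas the earlier pair had shown only that butyl and sec-butyl differ. Branching therefore does not account for the whole of compound 2's standing, since the isopropyl compound also keeps the branched pattern yet gives up part of the gain, though the comparison with the unbranched chain still shows an at least 2.1-fold lower number from compound 1 to compound 3 (0.33 log units; beyond the scatter). That comparison has only one measured end, and compound 1 stands at a limit of the assay: (the limit of > 30000 nM in this assay, at which 1 of the 3 values shown sits)

The compounds shown leave open whether a larger branched chain, such as a 3-pentyl or tert-butyl group, or a ring such as cyclohexyl, would continue the change seen from isopropyl to sec-butyl or reverse it. They also leave open how the mirror-image form of the sec-butyl group would read, and whether a hydroxyl or an amine on this chain would be tolerated.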